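Cyclopentyl in place of 4-acetylphenyl: working notes

This account rests on a few compounds, and the source may have more. Where it says the series, first, only, none or still open, it means among the compounds named here.

In a functional assay on HUVEC cells (Homo sapiens) for inhibition (on this read-out lower numbers stand for stronger inhibition and higher numbers for weaker inhibition), compound 1 `CN(c1ccc(NC(=O)Nc2ccccc2)cc1)c1ccnc(Nc2cccc(CS(C)(=O)=O)c2)n1` gives 0.2 nM, compound 2 `CN(c1ccc(NC(=O)Nc2ccccc2)cc1)c1ccnc(Nc2cccc(S(N)(=O)=O)c2)n1` gives 2 nM and compound 3 `CC(=O)c1ccc(NC(=O)Nc2ccc(N(C)c3ccnc(Nc4cccc(CS(C)(=O)=O)c4)n3)cc2)cc1` gives 2 nM. Going by the values given here, compound 3 is thus level with compound 2 at the top of the numbers so far, and compound 1 is the strongest of the three.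

The next step leads to compound 4 `CN(c1ccc(NC(=O)NC2CCCC2)cc1)c1ccnc(Nc2cccc(CS(C)(=O)=O)c2)n1`, with cyclopentyl in place of 4-acetylphenyl on an amide-type nitrogen. The aromatic ring and the acetyl both go.

Among the compounds with values here, two measured steps bear on this, neither directly. The closer one is a 10-fold higher number from compound 1 to compound 3 (1.00 log units; beyond the scatter), with acetyl in place of hydrogen on an aromatic carbon of the group now leaving, so changes to this group do register in this assay. The other, a 10-fold higher number from compound 1 to compound 2 (1.00 log units; beyond the scatter), is sulfamoyl in place of (methylsulfonyl)methyl, which is a different place but gives a similar size of step. Within the data shown here, no measured compound lacks the aromatic ring on this nitrogen, so the direction is only weakly grounded.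

A modest move towards a higher number is expected, a 2.5-fold higher number from compound 3 to compound 4 (0.40 log units; beyond the scatter), of about the size of those two steps or smaller. Compound 4 is estimated at 5 nM, with an expected range from 0.6 nM to 40 nM.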

Compound 4, half-maximal inhibitory concentration: 1 nM
Beside the measured number, compound 4's estimate is 5.0-fold (0.70 log units) above it, and the stated range covers the measured number.
By their numbers in this assay, from the lowest: compound 1; then compounds 4, 2 and 3 (each within the scatter of the next).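

In this assay, cyclopentyl in place of 4-acetylphenyl on the amide-type nitrogen gives a 2.0-fold lower number from compound 3 to compound 4 (0.30 log units; within the scatter), so removing the aromatic ring and the acetyl together produces no change that can be read at this position, and an aromatic ring on this nitrogen is not needed to stay level with compound 3. The position still registers against the unsubstituted group: cyclopentyl in place of phenyl gives a 5.0-fold higher number from compound 1 to compound 4 (0.70 log units; beyond the scatter), which, together with the acetyl step, leaves compound 1 apart from both compound 3 and compound 4 among the compounds with (methylsulfonyl)methyl. Nothing available accounts for either step.

Open, as far as these compounds go, is whether a longer alkyl chain or a carboxylic acid on this nitrogen would fall with phenyl or with the cyclopentyl and 4-acetylphenyl pair. Also open, from the compounds shown here alone, is whether the cyclopentyl step would hold with sulfamoyl in place of (methylsulfonyl)methyl, the change that separates compound 2 from compound 1.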